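Vero cytotoxicity notes: the step from compound 2 to compound 3

A few compounds are considered here, and "the series" means these few. Any claim that something is new, unique, unknown or untested is made for them only; others in the source may bear on it.

Measured so far in an ADME assay on Vero cells (Chlorocebus sabaeus) for cytotoxicity, read by MTT assay, with a stated time of 72 h; a lower number here means that less compound is tolerated, a higher number that more compound is tolerated:
compound 1 `COC(=O)c1cc(-c2cccc(NC(=O)c3ccc(/C=C/C(=O)c4cccc(F)c4)cc3)c2)on1` gives > 40 ug/mL, a limit of the assay
compound 2 `COC(=O)c1cc(-c2cccc(NC(=O)c3ccc(/C=C/C(=O)c4ccccc4O)cc3)c2)on1` gives "not determined" (no result reported)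

Compound 1 sits at the limit of > 40 ug/mL in this assay, at which 1 of the 2 values shown sits, which is a limit and not a number. Compound 2 has no value in this assay and so stands nowhere on the numbers shown. Compound 3 `COC(=O)c1cc(-c2cccc(NC(=O)c3ccc(/C=C/C(=O)c4ccc([N+](=O)[O-])cc4)cc3)c2)on1` differs from compound 2 by 4-nitrophenyl in place of 2-hydroxyphenyl on a carbonyl carbon. Among the compounds with values here, no measured step exists for this change, and no shift beyond the scatter is assumed. In this assay compound 3 is expected to give about 40 ug/mL. The expected range for compound 3 runs from 15 ug/mL to 80 ug/mL.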

Compound 3, half-maximal cytotoxic concentration: > 20 ug/mL
Compound 3 gave a limit, no number (the forecaster's own chance of this, stated with the estimate: 60%); the middle value does not contradict the limit.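

In this assay compound 3 gives > 20 ug/mL, a limit and not a number. Compound 1 gives > 40 ug/mL, also a limit, so no step can be read between compound 1 and compound 3. Open remains whether 4-nitrophenyl in place of 3-fluorophenyl on a carbonyl carbon changes tolerance at all.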